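The compounds below may be only part of what the source reports. "The series", "measured", "known", "first", "only" and "open" are said of these compounds alone.

Working notes on the series. In an assay on HEK293 cells for displacement of a labelled ligand from Melanocortin receptor 4 (Homo sapiens) (on this read-out higher numbers stand for weaker inhibition and lower numbers for stronger inhibition), compound 1 `CC(C)C[C@H](N)c1ccccc1N1CCN(C(=O)[C@H](C)Cc2ccc(Cl)cc2F)CC1` gives 67 nM and compound 2 `CC(C)C[C@H](N)c1cc(Cl)ccc1N1CCN(C(=O)C(C)Cc2ccc(Cl)cc2)CC1` gives 67 nM; the two numbers lie within the scatter of each other, so no order between them is claimed. Compound 3 `Cc1ccc(OCC(=O)N2CCN(c3ccc(C(F)(F)F)cc3[C@@H](N)CC(C)C)CC2)cc1` stands apart: in this assay compound 3 gives 4400 nM, the highest of the three numbers, and its gap to both compound 1 and compound 2 lies beyond the scatter.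

Compound 4 `Cc1cc(CC(C)C(=O)N2CCN(c3ccc(C(F)(F)F)cc3[C@@H](N)CC(C)C)CC2)ccc1Cl` is not yet measured. It differs from compound 3 in one place: 1-(4-chloro-3-methylbenzyl)ethyl in place of (4-methylphenoxy)methyl on a carbonyl carbon. The group that enters resembles the acyl part carried by compound 1 and compound 2, both of which sit far lower in this assay than compound 3, while the core of compound 4 is that of compound 3.

On that basis a step downward, well beyond the scatter, is expected in this assay, with the expected step of a 29-fold lower number from compound 3 to compound 4 (1.47 log units; beyond the scatter) placing compound 4 well below compound 3 but not certainly at the level of compound 1. Compound 4 is estimated at 150 nM in this assay, within a range of 40 nM to 600 nM.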

Compound 4, inhibition constant: 71 nM
Estimate against measurement, compound 4: 2.1-fold (0.32 log units) above; low and high end bracket the measured number.
By their numbers in this assay, from the lowest: compounds 1, 2 and 4 (each within the scatter of the next); then compound 3.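

In this assay, within the data shown here, the group 1-(4-chloro-3-methylbenzyl)ethyl in place of (4-methylphenoxy)methyl on a carbonyl carbon gives a 62-fold lower number from compound 3 to compound 4 (1.79 log units; beyond the scatter) with the rest of the structure unchanged, the one step that isolates a single place. The high number of compound 3 is therefore not fixed by its core, and this position alone can carry a large change in this assay. No measurement shown explains the size of the step.

The exchange alters several features at once, including the loss of the oxygen and the entry of the chlorine, so the compounds shown do not separate their contributions. A (4-chloro-3-methylphenoxy)methyl group or an unsubstituted 1-benzylethyl group on the same carbonyl carbon would be needed to divide the step between the linking chain and the ring substituents.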